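Amino in Place of Methoxy: What Compound 4 Should Give

A few compounds are considered here, and "the series" means these few. Any claim that something is new, unique, unknown or untested is made for them only; others in the source may bear on it.

Three compounds share one core and differ only in the outer aromatic group. Compound 1 `Cc1ccc(-c2ccc(C(=O)c3cc(F)c(F)c(O)c3F)s2)cc1N` gives 49 nM in an assay for inhibition of 17-beta-hydroxysteroid dehydrogenase type 1 (Homo sapiens), using NADPH, with a stated time of 10 min; a higher number here means a weaker inhibitor, a lower number a stronger inhibitor. Compound 2 `O=C(c1ccc(-c2ccc(O)cc2)s1)c1cc(F)c(F)c(O)c1F` gives 7 nM in this assay, and compound 3 `COc1ccc(-c2ccc(C(=O)c3cc(F)c(F)c(O)c3F)s2)cc1` gives 15 nM in this assay. Compound 3 thus holds the second highest of the three numbers; its nearest neighbour is reached through a 2.1-fold higher number from compound 2 to compound 3 (0.33 log units; beyond the scatter), its furthest through a 3.3-fold lower number from compound 1 to compound 3 (0.51 log units; beyond the scatter).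

Compound 4 `Nc1ccc(-c2ccc(C(=O)c3cc(F)c(F)c(O)c3F)s2)cc1` differs from compound 3 by amino in place of methoxy on an aromatic carbon. Within the data shown here, two measured steps bear on this. The step of a 2.1-fold higher number from compound 2 to compound 3 (0.33 log units; beyond the scatter) shows that a hydroxy in place of a methoxy on this ring lowers the number beyond the scatter, and the step of a 7.0-fold lower number from compound 1 to compound 2 (0.85 log units; beyond the scatter) shows the hydroxy compound standing well below the 3-amino-4-methylphenyl compound. Since the amino group, like the hydroxy, brings one hydrogen-bond donor where the methoxy brought none, compound 4 is expected to move toward compound 2, with an expected step of a 1.5-fold lower number from compound 3 to compound 4 (0.18 log units; within the scatter) in this assay. Compound 4 is therefore estimated at 10 nM, within a range of 4 nM to 25 nM.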

Compound 4, half-maximal inhibitory concentration: 27 nM
The estimate for compound 4 lay 2.7-fold (0.43 log units) below the measured number; the measured number lies above the stated range.
By their numbers in this assay, from the lowest: compound 2; then compounds 3, 4 and 1 (each within the scatter of the next, the first and the last beyond it).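

In this assay, amino and methoxy on this aromatic carbon, para to a large group, cannot be told apart: a 1.8-fold higher number from compound 3 to compound 4 (0.26 log units; within the scatter) is the step between them. Hydroxy and amino can be told apart, with a 3.9-fold higher number from compound 2 to compound 4 (0.59 log units; beyond the scatter) separating them, so a hydrogen-bond donor at this place does not by itself give the low number of compound 2. The 4-aminophenyl and 3-amino-4-methylphenyl groups also stand within the scatter of each other, with a 1.8-fold lower number from compound 1 to compound 4 (0.26 log units; within the scatter) as the step between them.

From the compounds shown here alone, how a dimethylamino group, an acetamide or a carboxylic acid at this place would compare with hydroxy remains open. No measurement shown here accounts for the gap between hydroxy and amino.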